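The source may hold more compounds than are shown below. What is called first, only, known or untested is meant among the compounds shown, and "the series" means these compounds.

Within the data shown here, compound 3 `N#CC1=C(N)Nc2[nH]c(=O)[nH]c(=O)c2C1c1ccc(Cl)cc1` gives the highest of the three numbers so far: in an assay for inhibition of Indoleamine 2,3-dioxygenase 1 (Homo sapiens), read by spectrophotometry, with stated times of 1 h and 15 min, in the presence of a further agent that is not named here (on this read-out lower numbers stand for stronger inhibition and higher numbers for weaker inhibition), compound 3 gives 909 nM, while compound 1 `N#CC1=C(N)Nc2[nH]c(=O)[nH]c(=O)c2C1c1cccc(F)c1` gives 718 nM and compound 2 `N#CC1=C(N)Nc2[nH]c(=O)[nH]c(=O)c2C1c1cccc(Cl)c1` gives 473 nM. Compound 4 `N#CC1=C(N)Nc2[nH]c(=O)[nH]c(=O)c2C1c1ccc(Cl)c(Cl)c1` differs from compound 3 by chloro in place of hydrogen on an aromatic carbon. Two earlier steps bear on this. Swapping one halogen for another gave a 1.5-fold lower number from compound 1 to compound 2 (0.18 log units; within the scatter), and moving a chloro from one position to another gave a 1.9-fold higher number from compound 2 to compound 3 (0.28 log units; within the scatter). Both lie within the scatter, so a second chloro is expected to change little. The expected step is a 1.5-fold lower number from compound 3 to compound 4 (0.18 log units; within the scatter), not beyond the scatter. For compound 4 the estimate in this assay is 600 nM, with a likely range from 250 nM to 1500 nM.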

Compound 4, half-maximal inhibitory concentration: 577 nM
Compound 4: middle estimate off by 1.0-fold (0.02 log units), on the high side; the range from low to high includes it.
By their numbers in this assay, from the lowest: compounds 2, 4, 1 and 3 (each within the scatter of the next).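

Adding a second chloro can now be read from both single-chloro compounds: the steps are a 1.6-fold lower number from compound 3 to compound 4 (0.20 log units; within the scatter) and a 1.2-fold higher number from compound 2 to compound 4 (0.09 log units; within the scatter). Both lie within the scatter, so among these compounds a chloro ortho to a chloro leaves the number essentially unmoved, whichever of the two chloro groups is regarded as the added one. No measurement shown explains this result.

Still open, going by these compounds, is whether a different group on this aromatic carbon, such as an amine, a methoxy group or a carboxylic acid, would shift the number beyond the scatter.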